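This account rests on a few compounds, and the source may have more. Where it says the series, first, only, none or still open, it means among the compounds named here.

The measured compounds, in a functional assay on K562 cells (Homo sapiens), read by MTT assay, with a stated time of 72 h; a higher number here means a weaker inhibitor, a lower number a stronger inhibitor:

Compound 1 `O=c1[nH]cnc2c1c(-c1ccoc1)cn2[C@@H]1O[C@H](CO)[C@@H](O)[C@H]1O` — 12500 nM
Compound 3 `Nc1nc2c(c(-c3ccoc3)cn2[C@@H]2O[C@H](CO)[C@@H](O)[C@H]2O)c(=O)[nH]1` — 19600 nM
Compound 2 `Cc1nc(N)c2c(-c3ccco3)cn([C@@H]3O[C@H](CO)[C@@H](O)[C@H]3O)c2n1` — a limit of the assay, > 20000 nM

Compound 1 holds the lowest of the two numbers given, and its nearest neighbour is compound 3, whose number differs from it by a 1.6-fold higher number from compound 1 to compound 3 (0.20 log units; within the scatter), a change that does not rise above the scatter. Going by the values given here, the figure for compound 2 is a limit rather than a number, (the limit of > 20000 nM in this assay, at which 1 of the 3 values shown sits), so it offers no measured step to compare with.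

The unmeasured compound 4 `O=c1[nH]cnc2c1c(-c1cc3ccccc3o1)cn2[C@@H]1O[C@H](CO)[C@@H](O)[C@H]1O` differs from compound 1 in one place: 1-benzofuran-2-yl in place of furan-3-yl on an aromatic carbon. Among the compounds with values here, none of the measured steps touches that position; the only step measured, that from compound 1 to compound 3, concerns an amino group at another carbon and is itself within the scatter. Within the data shown here, the data thus hold no precedent for exchanging furan-3-yl for 1-benzofuran-2-yl, and no direction for this assay can be drawn from them.

Compound 4 is therefore expected to sit near compound 1, with an estimated 11000 nM (range 3500 nM to 35000 nM). The step this estimate implies, a 1.1-fold lower number from compound 1 to compound 4 (0.06 log units; within the scatter), is expected to stay within the scatter.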

Compound 4, half-maximal inhibitory concentration: > 20000 nM
Compound 4: no number, only a limit; the forecaster's own chance of this, stated with the estimate: 25%; middle value at least 1.8-fold (0.25 log units) from the limit.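

In this assay, going by these compounds alone, the exchange of furan-3-yl for 1-benzofuran-2-yl gives the first step read at this aromatic carbon, an at least 1.6-fold higher number from compound 1 to compound 4 (0.20 log units; that floor lies within the scatter), so the earlier compounds' silence on this position is replaced by a single bounded reading. The value of compound 4 is a limit of the assay and not a number: the limit of > 20000 nM in this assay, at which 2 of the 4 values shown sit. The step therefore shows that the added six-membered aromatic ring of carbon only gave no measurable gain over furan-3-yl, though its floor alone does not separate compound 4 from compound 1.

From the compounds shown here alone, the true size of this step stays open, and so does whether the exchange would read the same on the core of compound 3, which carries the amino group. Within the data shown here, also open is how this aromatic carbon would respond to a group of another kind, such as a phenyl ring, an amine or a carboxylic acid, since furan-3-yl and 1-benzofuran-2-yl are the only groups compared here on the core of compound 1.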